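Furan-2-yl replaces 4-chlorophenyl in a spiro-fused series

The compounds below may be only part of what the source reports. "The series", "measured", "known", "first", "only" and "open" are said of these compounds alone.

Compound 1 `CN1C[C@@H](c2ccccc2)[C@@]2(Cc3ccccc3C2=O)[C@@]12C(=O)Nc1ccccc12`: 39.3%
Compound 2 `CN1C(=O)[C@@]2(c3ccccc31)N(C)C[C@@H](c1ccco1)[C@@]21Cc2ccccc2C1=O`: 8.2%
Compound 3 `CN1C[C@@H](c2ccc(Cl)cc2)[C@@]2(Cc3ccccc3C2=O)[C@@]12C(=O)Nc1ccccc12`: 15.6%

Of the compounds shown here, three have been measured in a functional assay on the whole organism (strain Wister albino) for inhibition, with Rattus norvegicus as the target, read by paw edema, with stated times of 1 h and 4 h, at a dose of 50 mg/kg by the intraperitoneal route; a lower number here means less inhibition, a higher number more inhibition at the dose given (going by the name of the read-out). Compound 1 gives 39.3%, compound 2 gives 8.2% and compound 3 gives 15.6%. Compound 3 stands second highest of the three; its nearest neighbour is compound 2, within the scatter, and its furthest is compound 1, beyond the scatter. Within the data shown here, the one measured step that changes a single place, a number 23.7 percentage points lower from compound 1 to compound 3 (beyond the scatter), shows a modest fall when chloro replaces hydrogen on the aromatic carbon.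

The next compound, compound 4 `CN1C[C@@H](c2ccco2)[C@@]2(Cc3ccccc3C2=O)[C@@]12C(=O)Nc1ccccc12`, differs from compound 3 by furan-2-yl in place of 4-chlorophenyl on a saturated ring carbon. Among the measured compounds shown here, no measured step covers this change directly; the step from compound 1 to compound 3 touches the same position but a different group, so it bears only loosely. Compound 2 carries furan-2-yl too, yet differs at a second place, so its value alone shows a low number with that group. Compound 4 is therefore expected to stay low, with an estimated step of a number 1.6 percentage points lower from compound 3 to compound 4 (within the scatter), within the scatter. The estimate for compound 4 is 14%, between 3% and 30%.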

Compound 4, a percentage reported as inhibition, in the whole organism at one dose (the size of the read-out at that dose, not a potency): 33.5%
Estimate against measurement, compound 4: 19.5 percentage points below, outside the stated range (above it).
By their numbers in this assay, from the lowest: compounds 2 and 3 (each within the scatter of the next); then compounds 4 and 1 (each within the scatter of the next).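

In this assay, furan-2-yl on the saturated ring carbon does not keep the number low, as the value of compound 2 had suggested: replacing 4-chlorophenyl gives a clear rise (a number 17.9 percentage points higher from compound 3 to compound 4 (beyond the scatter)), and replacing phenyl leaves a difference that lies within the scatter (a number 5.8 percentage points lower from compound 1 to compound 4 (within the scatter)). The low number of compound 2 therefore goes with the methyl on the amide-type nitrogen, since hydrogen in its place recovers much of the read-out (a number 25.3 percentage points higher from compound 2 to compound 4 (beyond the scatter)). Nothing given here explains why these steps take this size.

From the compounds shown here alone, it remains open whether chloro lowers the number at other places on the phenyl ring, or whether a thiophene or a pyridine at this ring carbon would read like furan-2-yl. An amine or a carboxylic acid on that aromatic ring is equally untested among the compounds shown here.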